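A few compounds are considered here, and "the series" means these few. Any claim that something is new, unique, unknown or untested is made for them only; others in the source may bear on it.

Measured compounds:
- Compound 1 `O=C(NCc1ccc(F)cc1)c1ncc([N+](=O)[O-])[nH]1`: > 100000 nM
- Compound 2 `NC(=O)c1nc([N+](=O)[O-])cn1Cc1ccc(OC(F)(F)F)cc1`: > 100000 nM
- Compound 3 `CN(C)C(=O)c1nc([N+](=O)[O-])cn1Cc1ccc(OC(F)(F)F)cc1`: > 100000 nM

All three entries are limits and not numbers.

In a toxicity assay on HEK293 cells (Homo sapiens) for inhibition, read by resazurin assay, with a stated time of 24 h (on this read-out higher numbers stand for lower toxicity in this test and lower numbers for higher toxicity in this test), compound 3 gives > 100000 nM, which is a limit. It therefore has no exact position among the measured compounds, all of which share (the limit of > 100000 nM in this assay, at which 3 of the 3 values shown sit).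

Compound 4 `O=C(NO)c1nc([N+](=O)[O-])cn1Cc1ccc(OC(F)(F)F)cc1` has not yet been measured. It carries hydroxyamino in place of dimethylamino on a carbonyl carbon.

Going by the values given here, the only measured step at this carbonyl carbon is a step that the two limits leave unreadable from compound 2 to compound 3. Among the compounds with values here, it offers no size to carry over, and no measured compound yet carries hydroxyamino, so the expectation must stay broad. The most likely result in this assay is another limit, with a modest move toward lower numbers, meaning higher toxicity, as the alternative. The expected step is an at least 1.2-fold lower number from compound 3 to compound 4 (0.09 log units; that floor lies within the scatter). For compound 4 the estimate is 80000 nM, with an expected range from 20000 nM to 200000 nM.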

Compound 4, half-maximal cytotoxic concentration: 36000 nM
Compound 4: middle estimate off by 2.2-fold (0.35 log units), on the high side; the range from low to high includes it.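

In this assay, going by these compounds alone, the group on the carbonyl carbon now shows an effect that the earlier compounds could not show: the step from amino to dimethylamino cannot be read, whereas hydroxyamino gives an at least 2.7-fold lower number from compound 3 to compound 4 (0.44 log units; beyond the scatter). Seen as a single change, hydroxy in place of hydrogen on the amide-type nitrogen gives an at least 2.7-fold lower number from compound 2 to compound 4 (0.44 log units; beyond the scatter), so this one replacement is enough to bring a compound into the range where the test returns a number. Compound 4 is the only compound shown with an exact value, and the others remain limits: the limit of > 100000 nM in this assay, at which 3 of the 4 values shown sit.

The compounds shown leave open whether the hydroxy itself is needed, or whether a methoxy group on the amide-type nitrogen would give a similar step. They also leave open what a carboxylic acid in place of the amide would do.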